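This account rests on a few compounds, and the source may have more. Where it says the series, first, only, none or still open, it means among the compounds named here.

Compound 1 `Cc1cccc2[nH]c(-c3n[nH]c4ncc(-c5cncc6ccccc56)cc34)nc12`: "not determined" (no result reported) in an assay on isolated protein for inhibition of proto-oncogene tyrosine-protein kinase receptor Ret (Homo sapiens); a lower number here means a stronger inhibitor, a higher number a weaker inhibitor.
Compound 2 `COCc1cccc2[nH]c(-c3n[nH]c4ncc(-c5ccncc5)cc34)nc12`: > 100000 nM, which is a limit of this assay and not a number.
Compound 3 `COCc1cccc2[nH]c(-c3n[nH]c4ncc(-c5cncnc5)cc34)nc12`: > 100000 nM, likewise a limit of this assay.

Compound 1 has no number of its own in this assay, and the two values beside it are limits rather than measurements, so it cannot be placed among them. Within the data shown here, the one step between measured compounds, a step that the two limits leave unreadable from compound 2 to compound 3, has no readable size, because both of its ends sit at the limit of > 100000 nM in this assay, at which 2 of the 3 values shown sit. Compound 4 `CC(C)NCc1cccc2[nH]c(-c3n[nH]c4ncc(-c5cncc6ccccc56)cc34)nc12` differs from compound 1 by isopropylamino in place of hydrogen on a saturated chain carbon bound to an aromatic carbon. Among the measured compounds shown here, no measured step bears on this change: the step from compound 2 to compound 3 alters the aromatic group, not the saturated chain carbon, and neither end of it gives a number. For the measured compounds named here, what the measured compounds show is only that two members fall at the limit. An estimate for compound 4 therefore rests on little, and the chance that compound 4 too returns only a limit is considerable. Compound 4 is expected to give about 5000 nM in this assay, within an estimated range from 200 nM to 100000 nM.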

Compound 4, half-maximal inhibitory concentration: > 100000 nM
Compound 4 gave a limit, no number; the forecaster's own chance of this, stated with the estimate: 35%; middle value at least 20-fold (1.30 log units) from the limit.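

No new step can be read between compound 1 and compound 4: compound 1 has no number in this assay, and compound 4 gives > 100000 nM, which is a limit of the assay and not a number. The compounds shown leave open how strongly any of them inhibits in this assay, and what isopropylamino in place of hydrogen changes.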